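Swapping methoxy for nitro on compound 3

This account rests on a few compounds, and the source may have more. Where it says the series, first, only, none or still open, it means among the compounds named here.

Measured so far in a functional assay on MCF7 cells (Homo sapiens) for inhibition, read by MTT assay, with a stated time of 48 h; a higher number here means a weaker inhibitor, a lower number a stronger inhibitor
compound 1 `Cc1ccc(/C=C2\SC(=O)N(CCNC(=O)Nc3c(C)n(C)n(-c4ccccc4)c3=O)C2=O)cc1` at 37400 nM
compound 2 `Cc1ccc(/C=C2\SC(=O)N(CC(=O)Nc3c(C)n(C)n(-c4ccccc4)c3=O)C2=O)cc1` at 65500 nM
compound 3 `COc1ccc(/C=C2\SC(=O)N(CC(=O)Nc3c(C)n(C)n(-c4ccccc4)c3=O)C2=O)cc1` at 75600 nM

Compound 3 at 75600 nM has a higher number, meaning weaker inhibition, than compound 1 at 37400 nM and the gap goes beyond the usual scatter. It cannot be told apart from compound 2, as a 1.2-fold higher number from compound 2 to compound 3 (0.06 log units; within the scatter) shows.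

The next compound to be tested is compound 4 `Cc1c(NC(=O)CN2C(=O)S/C(=C\c3ccc([N+](=O)[O-])cc3)C2=O)c(=O)n(-c2ccccc2)n1C` which alters a single group. The change is nitro in place of methoxy on an aromatic carbon (nitro in place of methoxy on an aromatic carbon, para to a large group).

Among the compounds with values here, the only measured swap of this kind is a 1.2-fold higher number from compound 2 to compound 3 (0.06 log units; within the scatter) in which methoxy took the place of methyl on an aromatic carbon. Within the data shown here, no nitro compound has been measured yet, so that small step is only a loose guide.

In this assay the expected result is therefore no step beyond the scatter and no firm direction, with an estimate of a 1.3-fold lower number from compound 3 to compound 4 (0.10 log units; within the scatter) as a slight lean. The estimated value for compound 4 is 60000 nM within an expected range (25000 nM to 130000 nM).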

Compound 4, half-maximal inhibitory concentration: 82400 nM
Compound 4: the middle estimate sits 1.4-fold (0.14 log units) below what was measured, within the range that was stated.
By their numbers in this assay, from the lowest: compounds 1, 2, 3 and 4 (each within the scatter of the next, the first and the last beyond it).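

In this assay, the 4-nitrophenyl group of compound 4 cannot be told apart from the 4-methoxyphenyl group (a 1.1-fold higher number from compound 3 to compound 4 (0.04 log units; within the scatter)), although nitro has more heavy atoms and hydrogen-bond acceptors than methoxy. It also cannot be told apart from the methyl group (a 1.3-fold higher number from compound 2 to compound 4 (0.10 log units; within the scatter)), so methyl, methoxy and nitro at this place on the aromatic ring now all give values within the scatter of one another, with no compound among these three going against that. No measurement shown offers an explanation for this flat result.

Still open, from the compounds shown here alone, is whether an amine, a carboxylic acid or a chlorine atom at this place would move the number beyond the scatter. Also open, going by these compounds, is whether nitro or methoxy would behave the same way on the longer chain of compound 1.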